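The source may hold more compounds than are shown below. What is called first, only, known or untested is meant among the compounds shown, and "the series" means these compounds.

Of the compounds shown here, three have been tested in a functional assay on the whole organism for antagonist activity, with Mus musculus as the target (on this read-out lower numbers stand for an effect already at smaller amounts and higher numbers for an effect only at larger amounts of compound), and none has yet given an exact number. Compound 1 `Cn1c(-c2cccc(F)c2)nnc1S(C)(=O)=O` reads > 200 mg/kg, which is a limit of the assay. Compound 2 `CSc1nnc(-c2ccc(F)cc2)n1C` reads > 200 mg/kg, again a limit. Compound 3 `Cn1c(-c2cccs2)nnc1[S+](C)[O-]` reads > 200 mg/kg, also a limit. Among the compounds with values here, that leaves the limit of > 200 mg/kg in this assay, at which 3 of the 3 values shown sit, as the only evidence so far.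

Compound 4 `Cn1c(-c2cccs2)nnc1S(C)(=O)=O` differs from compound 3 in one place, on an aromatic carbon, where methylsulfonyl enters: a group of 4 heavy atoms (1 carbon, 2 oxygen, 1 sulfur; no ring) in place of a group of 3 heavy atoms (1 carbon, 1 oxygen, 1 sulfur; no ring), on an aromatic carbon. Compound 1 also carries methylsulfonyl and reads > 200 mg/kg, a limit, so no change beyond the usual scatter is expected in this assay. The expected step of a number no higher from compound 3 to compound 4 (the limit leaves the size open) is therefore small or absent. For compound 4 the estimated value is 200 mg/kg, with an expected range of 70 mg/kg to 300 mg/kg.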

Compound 4, dose for half-maximal effect: > 200 mg/kg
Compound 4 was reported as a limit; the forecaster's own chance of this, stated with the estimate: 65%; the middle value sits exactly at the limit.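

No step can be read from compound 3 to compound 4, because both results are limits rather than numbers: the limit of > 200 mg/kg in this assay, at which 4 of the 4 values shown sit.

The compounds shown leave open what exact dose, if any, gives a half-maximal effect in this assay.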